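The source may hold more compounds than are shown below. What is called first, only, known or untested is meant among the compounds shown, and "the series" means these compounds.

Compound 3 `CC(C(=O)NCc1ccc(C(C)(C)C)cc1N1CCN(c2ccccc2)CC1)c1ccc(NS(C)(=O)=O)c(F)c1` gives 0.8 nM in an assay on cells for antagonist activity at transient receptor potential cation channel subfamily V member 1 (Homo sapiens), read by FLIPR and calcium flux, with a stated time of 6 min (a lower number here means a stronger inhibitor, a higher number a weaker inhibitor), the lowest number among the three measured compounds, though compound 1 `CCCCN(C)c1cc(C(C)(C)C)ccc1CNC(=O)C(C)c1ccc(NS(C)(=O)=O)c(F)c1`, at 1 nM, sits within the scatter of it: a 1.3-fold lower number from compound 1 to compound 3 (0.10 log units; within the scatter). Compound 2 `CC(C(=O)NCc1ccc(C(C)(C)C)cc1N1CCCCC1)c1ccc(NS(C)(=O)=O)c(F)c1` gives 1.9 nM; a 2.4-fold lower number from compound 2 to compound 3 (0.38 log units; beyond the scatter), and a 1.9-fold higher number from compound 1 to compound 2 (0.28 log units; within the scatter). The next compound, compound 4 `CCCOc1cc(C(C)(C)C)ccc1CNC(=O)C(C)c1ccc(NS(C)(=O)=O)c(F)c1`, carries propoxy in place of 4-phenylpiperazin-1-yl on an aromatic carbon. All three measured steps change the group at this same aromatic carbon; two stay within the scatter and the third is modest, so the position has so far accepted three different nitrogen-linked groups with little movement in this assay. On these data alone, an oxygen-linked chain is untested here, so the expectation is a small step or none beyond the scatter: a 2.5-fold higher number from compound 3 to compound 4 (0.40 log units; beyond the scatter). Compound 4 is estimated at 2 nM, with a range from 0.6 nM to 7 nM.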

Compound 4, inhibition constant: 4.4 nM
Estimate against measurement, compound 4: 2.2-fold (0.34 log units) below; measured number inside the range.
By their numbers in this assay, from the lowest: compounds 3, 1 and 2 (each within the scatter of the next, the first and the last beyond it); then compound 4.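

In this assay, compound 4 with propoxy is the weakest of the four, and all three steps to it are modest but beyond the scatter (a 5.5-fold higher number from compound 3 to compound 4 (0.74 log units; beyond the scatter)) (a 4.4-fold higher number from compound 1 to compound 4 (0.64 log units; beyond the scatter)) (a 2.3-fold higher number from compound 2 to compound 4 (0.36 log units; beyond the scatter)). This aromatic carbon therefore still accepts an oxygen-linked chain, at a small cost against each nitrogen-linked group. No available evidence explains the difference.

On these data alone, whether methoxy or a longer alkoxy chain would shift the number remains open. So does whether phenoxy, set against 4-phenylpiperazin-1-yl, would recover the lost activity.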